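The source may hold more compounds than are shown below. What is called first, only, known or untested is meant among the compounds shown, and "the series" means these compounds.

Measured compounds in a functional assay on HeLa cells (Homo sapiens) for antiproliferative activity, read by CCK-8 assay, with a stated time of 48 h; on this read-out higher numbers stand for weaker inhibition and lower numbers for stronger inhibition:
compound 1 `CCSc1n[nH]c(-n2[se]c3ccccc3c2=O)n1` gives 14100 nM;
compound 2 `Cc1ccc(CSc2n[nH]c(-n3[se]c4ccccc4c3=O)n2)cc1` gives 34800 nM;
compound 3 `O=c1c2ccccc2[se]n1-c1nc(SCc2ccc(Cl)cc2)n[nH]1` gives 40900 nM.

Compound 3 shows the highest number of the three; its gap to compound 2 is within the scatter, while a 2.9-fold higher number from compound 1 to compound 3 (0.46 log units; beyond the scatter) lies beyond it. Compound 4 `CCCSc1n[nH]c(-n2[se]c3ccccc3c2=O)n1` is reached from compound 3 by the change (ethyl in place of 4-chlorophenyl on a saturated chain carbon bound to a sulfur). For the measured compounds named here, the steps that bear on this are a 2.9-fold higher number from compound 1 to compound 3 (0.46 log units; beyond the scatter) and a 2.5-fold higher number from compound 1 to compound 2 (0.39 log units; beyond the scatter); both were modest, and the new change runs back toward compound 1, leaving the ethyl one carbon longer than in compound 1. The step of a 2.6-fold lower number from compound 3 to compound 4 (0.41 log units; beyond the scatter) is therefore expected to be a modest lowering. Compound 4 is estimated at 16000 nM in this assay, within a range from 7000 nM to 36000 nM.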

Compound 4, half-maximal inhibitory concentration: 30400 nM
The estimate for compound 4 lay 1.9-fold (0.28 log units) below the measured number; the measured number falls inside the stated range.
By their numbers in this assay, from the lowest: compound 1; then compounds 4, 2 and 3 (each within the scatter of the next).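

In this assay, the propyl compound cannot be told apart from the benzyl compounds: a 1.3-fold lower number from compound 3 to compound 4 (0.13 log units; within the scatter) and a 1.1-fold lower number from compound 2 to compound 4 (0.06 log units; within the scatter), so at this position the aromatic ring is not required for numbers of this size. The one chain carbon added to compound 1 is enough to give a step beyond the scatter, a 2.2-fold higher number from compound 1 to compound 4 (0.33 log units; beyond the scatter), and compound 1 alone stands apart from the other three. Nothing available explains this. The compounds shown leave open whether a longer chain, or an amine or carboxylic acid on the saturated chain carbon bound to a sulfur, would move the number, and in which direction.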